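The source may hold more compounds than are shown below. What is called first, only, known or untested is meant among the compounds shown, and "the series" means these compounds.

In a toxicity assay on Huh-7.5 cells (Homo sapiens) for inhibition, read by MTT assay, with a stated time of 96 h (a lower number here means that less compound is tolerated, a higher number that more compound is tolerated), compound 1 (`CCC(=O)Nc1cc(C(=O)Nc2ccc(CN3CCN(C)CC3)c(C(F)(F)F)c2)ccc1OC(C)C`) gives 15300 nM, and compound 2 (`CN1CCN(Cc2ccc(NC(=O)c3ccc(OCCCl)c([N+](=O)[O-])c3)cc2C(F)(F)F)CC1`) gives 9040 nM. Among the measured compounds shown here, these two numbers lie within the usual scatter of each other, so compound 1 stands level with the only other compound measured so far. Compound 3 (`CC(C)Oc1ccc(C(=O)Nc2ccc(CN3CCN(C)CC3)c(C(F)(F)F)c2)cc1NC(=O)C(C)Br`) has not yet been measured. It differs from compound 1 by a single change: bromo in place of hydrogen on a saturated chain carbon bound to a carbonyl carbon and a saturated chain carbon. This places bromo in place of hydrogen on a saturated chain carbon bound to a carbonyl carbon and a saturated chain carbon, turning propanoylamino into ((1-bromoethyl)carbonyl)amino. For the measured compounds named here, no measured pair shows what such a change does in this assay, so the expectation rests on the structural change alone. A moderate move to a lower number is expected, with an estimated step of a 3.1-fold lower number from compound 1 to compound 3 (0.49 log units; beyond the scatter). For compound 3 the expected value is 5000 nM, with an estimated range from 1500 nM to 14000 nM.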

Compound 3, half-maximal cytotoxic concentration: 8700 nM
Beside the measured number, compound 3's estimate is 1.7-fold (0.24 log units) below it; the range from low to high includes it.
By their numbers in this assay, from the lowest: compounds 3, 2 and 1 (each within the scatter of the next).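

In this assay, bromo in place of hydrogen on a saturated chain carbon bound to a carbonyl carbon and a saturated chain carbon gives a 1.8-fold lower number from compound 1 to compound 3 (0.25 log units; within the scatter) and is the first single change that can be read among these compounds. Turning propanoylamino into ((1-bromoethyl)carbonyl)amino therefore leaves compound 3 level with compound 1 in this assay, so this pair shows no clear effect of the change at this position. Nothing measured here offers an explanation for this result.

The compounds shown leave open how chloro, a hydroxy group or an amine on the same saturated chain carbon would read in this assay. They also leave open whether bromo on a longer chain would stay level with its parent, or whether this step would hold on a core other than that of compound 1.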